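A few compounds are considered here, and "the series" means these few. Any claim that something is new, unique, unknown or untested is made for them only; others in the source may bear on it.

Working notes on the series, single-concentration glutathione S-transferase P readings.

Compound 1 `C=C(CC)C(=O)c1ccc(OCc2nc(-c3ccc([N+](=O)[O-])cc3)cs2)cc1Cl` gives 10.2% in an assay on HL-60 cells for inhibition of glutathione S-transferase P (Homo sapiens), read by spectrophotometry, tested at 5 uM; on this read-out higher numbers stand for more inhibition at the one concentration tested (going by the name of the read-out) and lower numbers for less inhibition. Within the data shown here, compound 2 `C=C(CC)C(=O)c1ccc(OCc2nc(-c3ccc4ccccc4c3)cs2)cc1Cl` gives 9.5% in this assay; of the two numbers measured so far it is the one that sits at the bottom, but the gap is only a number 0.7 percentage points lower from compound 1 to compound 2 (within the scatter), so the two compounds cannot be told apart on this read-out. Among the measured compounds shown here, the only aryl exchange seen at this place, from 4-nitrophenyl to naphthalen-2-yl, therefore left the inhibition unchanged within the scatter.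

Compound 3 `C=C(CC)C(=O)c1ccc(OCc2nc(-c3ccc(C(F)(F)F)cc3)cs2)cc1Cl` is not yet measured. It differs from compound 2 by 4-(trifluoromethyl)phenyl in place of naphthalen-2-yl on an aromatic carbon. For the measured compounds named here, the one step that bears on this exchange is the one from compound 1 to compound 2, which moved the number by a number 0.7 percentage points lower from compound 1 to compound 2 (within the scatter); it exercised the same place of the shared core with two quite different aromatic groups and did nothing beyond the scatter. Without further support, compound 3 is expected to behave the same way, with a step of a number 0.5 percentage points higher from compound 2 to compound 3 (within the scatter) that stays within the scatter. Compound 3 is thus estimated at 10% in this assay, with a range of 3% to 18%.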

Compound 3, a percentage reported as inhibition, at one concentration (the size of the read-out at that concentration, not a potency): 19.7%
For compound 3 the middle estimate is 9.7 percentage points below the measured one; the whole stated range lies below it.
By their numbers in this assay, from the lowest: compounds 2, 1 and 3 (each within the scatter of the next, the first and the last beyond it).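

The exchange of naphthalen-2-yl for 4-(trifluoromethyl)phenyl on this aromatic carbon gives a number 10.2 percentage points higher from compound 2 to compound 3 (beyond the scatter) in this assay and shows that this place does not ignore every aryl exchange, although the step is only modest. The exchange of nitro for trifluoromethyl gives a number 9.5 percentage points higher from compound 1 to compound 3 (within the scatter) and so separates nothing; only compound 2 and compound 3 can be told apart, and the loss of the second aromatic ring does not sort the series on its own, since compound 1 also carries a single such ring yet stays within the scatter of compound 2. Nothing at hand gives a reason for the step seen between compound 2 and compound 3.

Going by these compounds, it remains open whether other groups on the phenyl ring, such as an amine, a carboxylic acid or a longer alkyl chain, would move the number beyond the scatter of compound 3 as well. On these data alone, it also remains open whether the gap between compound 2 and compound 3 would hold at other concentrations, as each number here is a reading at one concentration and not a potency.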